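A few compounds are considered here, and "the series" means these few. Any claim that something is new, unique, unknown or untested is made for them only; others in the source may bear on it.

Measured so far:
Compound 1, `Cc1c(OCCCCOc2ccc(C(=O)O)cc2)ccc(C(=O)CC2CCCC2)c1O` — in an assay on HEK293 cells for positive allosteric modulation of metabotropic glutamate receptor 2 (Rattus norvegicus), read by thallium flux, with a stated time of 2.5 min (on this read-out higher numbers stand for an effect only at larger amounts of compound and lower numbers for an effect already at smaller amounts), compound 1 gives 824 nM.
Compound 2, `Cc1c(OCCCCOc2ccc(C(=O)O)cc2)ccc(C(=O)CC(C)C)c1C` — in this assay compound 2 gives "not determined" (no result reported).
Compound 3, `Cc1c(OCCCCOc2cccc(C(=O)O)c2)ccc(C(=O)CC2CCCC2)c1O` — in this assay compound 3 gives 451 nM.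

Compound 4, `Cc1c(OCCCCOc2cccc(C(=O)O)c2)ccc(C(=O)CC(C)C)c1C`, has not yet been measured. Compounds 1 and 3 share a core and differ in one place: 3-carboxyphenyl in place of 4-carboxyphenyl on an oxygen on a saturated carbon. That change made the step of a 1.8-fold lower number from compound 1 to compound 3 (0.26 log units; within the scatter), so the two values are indistinguishable within the usual variation of this measurement. Compound 2 carries a different core; how its core differs from that of compound 1 is not broken down here. Compound 4 stands to compound 2 as compound 3 stands to compound 1: 3-carboxyphenyl in place of 4-carboxyphenyl on an oxygen on a saturated carbon. Among the measured compounds shown here, since the place is the same in both pairs, this is the same change, and from the one earlier example it is expected to make a step of about the same small size, within the scatter, for compound 4. Compound 2 has no number in this assay. For the measured compounds named here, the only anchor is the pair of compounds 1 and 3, and the estimate for compound 4 is wide. Compound 4 is expected to give about 800 nM in this assay, somewhere between 150 nM and 5000 nM.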

Compound 4, half-maximal effective concentration: "not active" (no number reported)
No number was reported for compound 4; no gap can be computed for the estimate.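

In this assay, among the compounds shown here, compound 2 gives "not determined" (no result reported) and compound 4 gives "not active" (no number reported) so neither has a number, and no step between these two compounds can be read. The compounds shown leave open how much 3-carboxyphenyl in place of 4-carboxyphenyl changes the result on the core of compound 2. Nothing in the data shown explains the result for compound 4.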